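Quinoxaline-sulfonyl anilines: aminophenyl position in cytotoxicity

The compounds below may be only part of what the source reports. "The series", "measured", "known", "first", "only" and "open" are said of these compounds alone.

Measured compounds:
compound 1 `Nc1ccc(Nc2nc3ccccc3nc2S(=O)(=O)c2ccccc2)cc1` 12900 nM
compound 2 `Nc1cccc(Nc2nc3ccccc3nc2S(=O)(=O)c2ccccc2)c1` 1590 nM
compound 3 `Cc1ccc(S(=O)(=O)c2nc3ccccc3nc2Nc2ccc(N)cc2)cc1` 24600 nM

In a functional assay on A549 cells (Homo sapiens) for cytotoxicity, read by MTT assay, with a stated time of 72 h (on this read-out lower numbers stand for stronger inhibition and higher numbers for weaker inhibition), compound 1 gives 12900 nM, compound 2 gives 1590 nM and compound 3 gives 24600 nM. Compound 4 `Cc1ccc(S(=O)(=O)c2nc3ccccc3nc2Nc2cccc(N)c2)cc1` has not yet been measured in this assay.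

Compound 2 differs from compound 1 by 3-aminophenyl in place of 4-aminophenyl on a nitrogen on an aromatic ring. That change produced an 8.1-fold lower number from compound 1 to compound 2 (0.91 log units; beyond the scatter). Compound 3 differs from compound 1 by methyl in place of hydrogen on an aromatic carbon, a change that gave a 1.9-fold higher number from compound 1 to compound 3 (0.28 log units; within the scatter), so the two cores do not separate on this read-out. Going by the values given here, compound 3 holds the highest number of the three measured so far, though its gap to compound 1 stays within the scatter; only its gap to compound 2 lies beyond it.

Compound 4 differs from compound 3 by 3-aminophenyl in place of 4-aminophenyl on a nitrogen on an aromatic ring. This is the same change as the one from compound 1 to compound 2, made at the same place, and among the compounds shown it occurs twice in all. Since the cores differ only by the methyl change that left the number essentially unmoved, the step from compound 3 to compound 4 is expected to resemble the earlier one, with some allowance for it not carrying over fully: compound 4 is estimated to show a 7.0-fold lower number from compound 3 to compound 4 (0.85 log units; beyond the scatter) in this assay. Because compound 3 gives 24600 nM, compound 4 is expected to come in near 3500 nM, with a range from 1200 nM to 10000 nM as the plausible span.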

Compound 4, half-maximal inhibitory concentration: 1950 nM
Compound 4: the middle estimate sits 1.8-fold (0.25 log units) above what was measured; low and high end bracket the measured number.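

In this assay, 3-aminophenyl in place of 4-aminophenyl gives a 13-fold lower number from compound 3 to compound 4 (1.10 log units; beyond the scatter), and the step carries over from the core of compound 1 to the methyl-bearing core: the same change on two cores in this assay, an 8.1-fold lower number (0.91 log units; beyond the scatter) from compound 1 to compound 2 and a 13-fold lower number (1.10 log units; beyond the scatter) from compound 3 to compound 4, 1.6-fold (0.19 log units) apart, within the scatter of two such steps. Going by these compounds alone, the methyl change, read within the 3-aminophenyl pair, gives a 1.2-fold higher number from compound 2 to compound 4 (0.09 log units; within the scatter), and it too behaves alike in both settings, leaving the aminophenyl position as the only one of the two changes with a step beyond the scatter: the same change on two cores in this assay, a 1.9-fold higher number (0.28 log units; within the scatter) from compound 1 to compound 3 and a 1.2-fold higher number (0.09 log units; within the scatter) from compound 2 to compound 4, 1.6-fold (0.19 log units) apart, within the scatter of two such steps. This agreement rests on just two pairs, on cores that differ by one methyl, on a single read-out, so it supports transfer between these two closely related cores but does not show that the step would hold on a core that differs more, and it gives no explanation of why the position of the amine matters.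

Still open, as far as these compounds go, is whether the same step appears when the methyl is replaced by a methoxy group or a chlorine atom on that ring. Also open, from the compounds shown here alone, is whether the difference between 3-aminophenyl and 4-aminophenyl survives when the amine itself gives way to a hydroxyl group or a carboxylic acid.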